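Chloro to Bromo on the Aromatic Ring of Compound 2

The compounds below may be only part of what the source reports. "The series", "measured", "known", "first", "only" and "open" are said of these compounds alone.

Compound 2 `O=C(N/N=C/c1cccc(Cl)c1)c1cnccn1` shares the highest number of the set in an ADME assay on J774 cells (Mus musculus) for cytotoxicity, read by MTT assay, with a stated time of 48 h, tested at 150 ug/mL (on this read-out higher numbers stand for a weaker effect at the one concentration tested and lower numbers for a stronger effect), with compound 1 `O=C(N/N=C/c1ccccc1)c1cnccn1`: compound 2 gives 100%. Compound 1 gives 100%. Compound 3 `O=C(N/N=C/c1ccccc1Br)c1cnccn1` gives 91%. Both measured steps start from compound 1: no change at the digits printed from compound 1 to compound 2 (within the scatter), and a number 9 percentage points lower from compound 1 to compound 3 (within the scatter); each lies within the scatter.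

Compound 4 `O=C(N/N=C/c1cccc(Br)c1)c1cnccn1` differs from compound 2 by bromo in place of chloro on an aromatic carbon. Going by the values given here, no measured step swaps one halogen for another, so the only guide is the pair of steps from compound 1, in which chloro entering and bromo entering on an aromatic carbon each left the read-out unchanged within the scatter. Compound 4 is therefore expected to stay within the scatter of compound 2, an estimated a number 3 percentage points lower from compound 2 to compound 4 (within the scatter). Compound 4 is estimated at 97%, with a range of 85% to 100%.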

Compound 4, a percentage reported as activity, at one concentration (the size of the read-out at that concentration, not a potency): 93%
For compound 4 the middle estimate is 4 percentage points above the measured one; the range from low to high includes it.
By their numbers in this assay, from the lowest: compounds 3, 4, 1 and 2 (each within the scatter of the next).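

Going by these compounds alone, compound 4 gives the first direct halogen swap at the ring position meta to a large group, with a number 7 percentage points lower from compound 2 to compound 4 (within the scatter) in this assay. Set against the parent, the same position gives a number 7 percentage points lower from compound 1 to compound 4 (within the scatter), so neither chloro nor bromo there, nor the exchange of one for the other, takes the read-out beyond the usual scatter. Nothing available explains these numbers or links them to any property of the two halogens.

The compounds shown leave open whether an amine, a carboxylic acid or a longer chain on this aromatic carbon would move the number in this assay beyond the scatter. They also leave open which change to the shared core, if any, would produce a clear step in this read-out, as every step shown stays within the scatter.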